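Nitrophenyl Replaces Aminophenyl on the Shared Core

The source may hold more compounds than are shown below. What is called first, only, known or untested is meant among the compounds shown, and "the series" means these compounds.

Compound 3 `CCCS(=O)(=O)Nc1ccc(F)c(C(=O)c2n[nH]c3ncc(-c4ccc(N)cc4)cc23)c1F` gives 0.1% in an assay for binding affinity to dual specificity mitogen-activated protein kinase kinase 4 (Homo sapiens), read by KINOMEscan, tested at 100 nM (on this read-out higher numbers stand for a weaker effect at the one concentration tested and lower numbers for a stronger effect), the lowest of the three numbers measured. Its nearest neighbour is compound 2 `CCCS(=O)(=O)Nc1ccc(F)c(C(=O)c2n[nH]c3ncc(-c4cccc(OC)c4)cc23)c1F`, which gives 6.3%; the step of a number 6.2 percentage points lower from compound 2 to compound 3 (within the scatter) lies within the scatter. Compound 1 `CCCS(=O)(=O)Nc1ccc(F)c(C(=O)c2n[nH]c3ncc(-c4cccc(Cl)c4)cc23)c1F` stands furthest away, giving 40%, and the step of a number 39.9 percentage points lower from compound 1 to compound 3 (beyond the scatter) is large. Compound 4 `CCCS(=O)(=O)Nc1ccc(F)c(C(=O)c2n[nH]c3ncc(-c4cccc([N+](=O)[O-])c4)cc23)c1F` carries the change (3-nitrophenyl in place of 4-aminophenyl on an aromatic carbon). Among the measured compounds shown here, no measured step carries this exact exchange; the steps that bear on it are a number 39.9 percentage points lower from compound 1 to compound 3 (beyond the scatter) and a number 33.7 percentage points lower from compound 1 to compound 2 (beyond the scatter), both large downward moves away from compound 1, whereas a number 6.2 percentage points lower from compound 2 to compound 3 (within the scatter) is small. Because compound 1 gives 40%, a move back upward is expected, though its size is uncertain. Compound 4 is therefore estimated at 30% (range 3% to 70%), the expected step being a number 29.9 percentage points higher from compound 3 to compound 4 (beyond the scatter).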

Compound 4, a percentage reported as activity, at one concentration (the size of the read-out at that concentration, not a potency): 15%
For compound 4 the middle estimate is 15 percentage points above the measured one, and the stated range covers the measured number.
By their numbers in this assay, from the lowest: compounds 3, 2 and 4 (each within the scatter of the next, the first and the last beyond it); then compound 1.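

At this position, two atoms from the ring nitrogen, nitro in place of chloro gives a number 25 percentage points lower from compound 1 to compound 4 (beyond the scatter) in this assay, so methoxy is no longer the only group shown to stand apart from chloro. Nitro in place of methoxy gives a number 8.7 percentage points higher from compound 2 to compound 4 (within the scatter), which does not separate the two groups, whereas 3-nitrophenyl in place of 4-aminophenyl gives a number 14.9 percentage points higher from compound 3 to compound 4 (beyond the scatter). No evidence is available to explain these differences. The compounds shown leave open how 3-aminophenyl or 4-nitrophenyl would read, which would separate the effect of the group from that of its place on the phenyl ring.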